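Swapping the ether for a thioether on the quinoxaline series

A few compounds are considered here, and "the series" means these few. Any claim that something is new, unique, unknown or untested is made for them only; others in the source may bear on it.

Compound 1 `Nc1cc(N)c2nc(-c3ccccc3)c(Oc3ccc(Cl)c(Cl)c3)nc2c1` belongs to a small set of diamino-substituted bicyclic compounds bearing a phenyl group on the shared core and a 3,4-dichlorophenyl unit attached through a linker. In a functional assay on U-251 cells (Homo sapiens) for inhibition, read by sulforhodamine B assay, with a stated time of 48 h (a higher number here means a weaker inhibitor of growth, a lower number a stronger inhibitor of growth), compound 1 gives 12000 nM, the highest of the three numbers in hand. Its nearest neighbour, compound 2 `Nc1cc(N)c2nc(-c3ccccc3)c(NCc3ccc(Cl)c(Cl)c3)nc2c1`, which carries the dichlorophenyl unit through an aminomethyl linker, gives 2090 nM in this assay, and compound 3 `COc1cc(CNc2nc3cc(N)cc(N)c3nc2-c2ccccc2)cc(OC)c1OC`, with a trimethoxybenzylamino group in the same place, gives 1740 nM. Both of those differences from compound 1 lie beyond the usual scatter, so compound 1 is the weakest growth inhibitor measured here.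

Compound 4 `Nc1cc(N)c2nc(-c3ccccc3)c(Sc3ccc(Cl)c(Cl)c3)nc2c1` keeps the core, the phenyl group and the dichlorinated ring of compound 1, but changes the linking atom: (3,4-dichlorophenyl)sulfanyl in place of 3,4-dichlorophenoxy on an aromatic carbon. For the measured compounds named here, no measured pair in this set isolates an oxygen-to-sulfur swap, so the expectation rests on compound 1 alone. A modest gain is expected, with the step from compound 1 to compound 4 estimated at a 1.5-fold lower number from compound 1 to compound 4 (0.18 log units; within the scatter) in this assay. Compound 4 is therefore expected to give about 8000 nM in this assay, within a range of 3000 nM to 25000 nM.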

Compound 4, concentration for 50% growth inhibition: 10200 nM
The estimate for compound 4 lay 1.3-fold (0.11 log units) below the measured number, within the range that was stated.
By their numbers in this assay, from the lowest: compounds 3 and 2 (each within the scatter of the next); then compounds 4 and 1 (each within the scatter of the next).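

In this assay, putting (3,4-dichlorophenyl)sulfanyl in place of 3,4-dichlorophenoxy on the aromatic carbon next to the ring nitrogen gives a 1.2-fold lower number from compound 1 to compound 4 (0.07 log units; within the scatter), so at this position the assay does not distinguish the oxygen link from the sulfur link. For the compounds shown here, this is the first pair in the set with a readable step, and it isolates the linking atom while the shared core, the phenyl group and the dichlorinated ring stay the same. The data on hand offer no measurement that bears on this result, so nothing can be said about what lies behind it.

The compounds shown leave open how a sulfonyl link, a methylene link or a directly attached amine link to the same dichlorinated ring would read at this position. They also leave open whether oxygen and sulfur links would still read alike if a pyridine ring or a trimethoxyphenyl ring took the place of the 3,4-dichlorophenyl ring.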